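The source may report more compounds than this note shows. Statements on the series, on what has been measured and on what is new or still open speak of the compounds shown alone.

Compound 1 `CCCCC(CC)CNc1ncc(C(Oc2ccc3cc(Br)ccc3c2)c2ccc(Cl)cc2)s1`: "not toxic" (no number reported)
Compound 2 `N#Cc1cccc(C(=O)Nc2ncc(C(Oc3ccc4cc(Br)ccc4c3)c3ccc(Cl)cc3)s2)c1`: > 50000 nM

Of the compounds shown here, two have been tested in an ADME assay on HepG2 2.2.15 cells (Homo sapiens) for cytotoxicity; on this read-out higher numbers stand for lower toxicity in this test and lower numbers for higher toxicity in this test. Compound 1 came out as "not toxic" (no number reported), with no number attached to that outcome. Compound 2 reached only a limit of the test, reported as > 50000 nM. Compound 2 therefore stands at the limit of > 50000 nM in this assay, at which 1 of the 2 values shown sits, and neither measured compound shows toxicity that the test could put a number on.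

Compound 3 `Cc1noc(C)c1C(=O)Nc1ncc(C(Oc2ccc3cc(Br)ccc3c2)c2ccc(Cl)cc2)s1` is not yet measured. It differs from compound 2 in one place: 3,5-dimethyl-1,2-oxazol-4-yl in place of 3-cyanophenyl on a carbonyl carbon, so the carbonyl carbon bearing the amide-type nitrogen now carries the 3,5-dimethyl-1,2-oxazol-4-yl group where compound 2 carries 3-cyanophenyl. Among the measured compounds shown here, no measured pair in this set shows what such a swap does in this assay, so the size of the step is open. With both tested compounds sitting where the test stops resolving numbers, no shift beyond the usual scatter is expected, and the likeliest outcome is again a limit. Compound 3 is expected to give 50000 nM, within 20000 nM to 120000 nM. This corresponds to an expected step of a number no higher from compound 2 to compound 3 (the limit leaves the size open).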

Compound 3, half-maximal cytotoxic concentration: "not toxic" (no number reported)
Compound 3 has no reported number here; no gap can be computed for the estimate.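

Among the compounds shown here, compound 3 carries no number and compound 2 only a limit, so no step between these two compounds can be read in this assay. On these data alone, what remains open is whether swapping 3-cyanophenyl for 3,5-dimethyl-1,2-oxazol-4-yl changes the read-out at all, and at what concentration, if any, these compounds would become toxic to the cells.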